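Working notes: adding methyl to compound 2

A few compounds are considered here, and "the series" means these few. Any claim that something is new, unique, unknown or untested is made for them only; others in the source may bear on it.

In a functional assay on U-251 cells (Homo sapiens) for inhibition, read by sulforhodamine B assay, with a stated time of 48 h (a higher number here means a weaker inhibitor of growth, a lower number a stronger inhibitor of growth), compound 1 `S=C(N/N=C/c1cccs1)Nc1ccc(Cl)cc1` gives 8300 nM and compound 2 `S=C(N/N=C/c1cccs1)Nc1ccccc1` gives 74700 nM. Compound 2 holds the higher of these two numbers, which makes it the weaker growth inhibitor of the pair. Going by the values given here, the only measured step is a 9.0-fold higher number from compound 1 to compound 2 (0.95 log units; beyond the scatter), with hydrogen in place of chloro on an aromatic carbon, and it lies beyond the scatter.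

The next compound is compound 3 `Cc1ccc(NC(=S)N/N=C/c2cccs2)cc1`. The change from compound 2 is methyl in place of hydrogen on an aromatic carbon, para to a large group. Among the compounds with values here, the single measured step is the only guide, and it concerns chloro rather than methyl, so it carries over only loosely. Read in reverse, a 9.0-fold higher number from compound 1 to compound 2 (0.95 log units; beyond the scatter) suggests a lower number when hydrogen is replaced, though probably by a smaller margin. Within the data shown here, no methyl example has been measured, so a step within the scatter remains possible.

The expected step is a 2.5-fold lower number from compound 2 to compound 3 (0.40 log units; beyond the scatter). In this assay, compound 3 is estimated at 30000 nM, with an expected range of 9000 nM to 90000 nM.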

Compound 3, concentration for 50% growth inhibition: 12600 nM
Beside the measured number, compound 3's estimate is 2.4-fold (0.38 log units) above it, within the range that was stated.
By their numbers in this assay, from the lowest: compounds 1 and 3 (each within the scatter of the next); then compound 2.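

At the aromatic carbon para to a large group, methyl in place of hydrogen gives a 5.9-fold lower number from compound 2 to compound 3 (0.77 log units; beyond the scatter) in this assay, a step beyond the scatter and in the same direction as the one seen with chloro. The lower number relative to compound 2 is therefore not tied to chloro alone, since two different groups at this carbon now both lie on the same side of hydrogen. Chloro and methyl cannot be told apart here, with a 1.5-fold higher number from compound 1 to compound 3 (0.18 log units; within the scatter), so this assay gives no reason to prefer either group at this position.

The compounds shown leave open whether a methoxy group, an amine, a carboxylic acid or a longer chain such as ethyl at this same carbon would also give a lower number than hydrogen, or whether the effect is limited to chloro and methyl. Nothing available on these compounds accounts for the step from hydrogen to methyl, and growth inhibition in this one cell line is the only read-out at hand.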